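Aryl amide in place of cycloalkyl amide on a shared azetidine-free core

The compounds below may be only part of what the source reports. "The series", "measured", "known", "first", "only" and "open" are said of these compounds alone.

Measured compounds:
compound 1 `O=C(c1ccc(Cl)cc1)N1CC(c2nc(-c3cccc(F)c3)no2)C1`: > 10000 nM
compound 2 `CC1CCCC(C(=O)N2CC(c3nc(-c4cccc(Cl)c4)no3)C2)C1`: > 10000 nM
compound 3 `Cc1ccc(S(=O)(=O)N2CC(c3nc(-c4cccc(Cl)c4)no3)C2)cc1`: 920 nM

Of the compounds shown here, three of the shared core have been tested in an assay on HEK293 cells for negative allosteric modulation of metabotropic glutamate receptor 5 (Homo sapiens), read by FLIPR; a lower number here means a stronger inhibitor, a higher number a weaker inhibitor. Compound 2 sits at the limit of the assay, as its value, > 10000 nM, is a limit and not a number. Compound 1 likewise gives only a limit, > 10000 nM. Compound 3, the sulfonamide of the series, gives a number in this assay, 920 nM. Thus the limit of > 10000 nM in this assay, at which 2 of the 3 values shown sit, marks where compound 2 stands: at the weak end of what this assay can report.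

Compound 4 `O=C(c1ccccc1F)N1CC(c2nc(-c3cccc(Cl)c3)no2)C1` is the next compound to be measured. It differs from compound 2 in one place: 2-fluorophenyl in place of 3-methylcyclohexyl on a carbonyl carbon. Among the compounds with values here, no step between measured compounds shows what this kind of exchange does in this assay, so the size of the change can only be guessed. Compound 1 is also an amide of the shared core and it too sits at the limit, which gives no sign that an aromatic ring on the carbonyl carbon lifts potency out of the limit region. The step of an at least 1.2-fold lower number from compound 2 to compound 4 (0.09 log units; that floor lies within the scatter) is therefore expected to be small, if it shows at all beyond the scatter. Compound 4 is estimated to give 8000 nM in this assay, within a range of 2000 nM to 30000 nM, with a fair chance that only a limit is returned.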

Compound 4, half-maximal inhibitory concentration: 670 nM
The estimate for compound 4 lay 12-fold (1.08 log units) above the measured number; measured number below the stated range.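

In this assay, the group on the carbonyl carbon of the amide proves to matter: 2-fluorophenyl in place of 3-methylcyclohexyl gives an at least 14-fold lower number from compound 2 to compound 4 (1.17 log units; beyond the scatter), the first step measured in this series, and it lies beyond the scatter. Within the data shown here, until now the only number came from the sulfonamide compound 3, whereas compound 4 shows that an amide of the shared core can also return a number rather than a limit. The printed size of the step is only a floor, because compound 2 stands at a limit and not at a number: the limit of > 10000 nM in this assay, at which 2 of the 4 values shown sit.

Compound 1, which also has an aromatic ring on the carbonyl carbon, gives > 10000 nM, which is a limit of the assay, and it differs from compound 4 in more than one place, which leaves open how far the aromatic ring alone accounts for the step. Also open, as far as these compounds go, are whether the fluorine contributes anything, and what a plain phenyl, a pyridine ring or a methoxy group on the ring would give in this assay.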